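A few compounds are considered here, and "the series" means these few. Any claim that something is new, unique, unknown or untested is made for them only; others in the source may bear on it.

Of the compounds shown here, two have been measured in a functional assay on HEK293 cells for positive allosteric modulation of metabotropic glutamate receptor 5 (Rattus norvegicus), read by fluorescence and calcium flux (on this read-out lower numbers stand for smaller maximal responses and higher numbers for larger maximal responses), a way of asking how strongly a modulator lifts the receptor's response. Compound 1 `C[C@@H](NC(=O)c1ccc(C#CC2CC2)cn1)C(C)(C)O` gives 63.4%. Compound 2 `CC(C)[C@H](C)NC(=O)c1ccc(C#Cc2cccc(F)c2)cn1` gives 66.7%, the higher of the two numbers; its nearest neighbour is compound 1, and the gap between them is within the scatter, so the two cannot be told apart on these data. Compound 3 `CC1(CCNC(=O)c2ccc(C#Cc3cccc(F)c3)cn2)COC1` has not yet been measured. It differs from compound 2 at one place, on the amide-type nitrogen whose other neighbour is the carbonyl carbon: 2-(3-methyloxetan-3-yl)ethyl in place of 1,2-dimethylpropyl on an amide-type nitrogen. Among the measured compounds shown here, no pair of measured compounds shows the effect of a change at this place, so the size of the step has to be guessed. Since compound 1, which carries a different chain on the same nitrogen, gives 63.4% and lands close to compound 2, a change here is expected to move the response little. The step from compound 2 to compound 3 in this assay is expected to be a number 6.7 percentage points lower from compound 2 to compound 3 (within the scatter), not clearly beyond the scatter. Compound 3 is therefore estimated at 60%, with a likely range from 42% to 78%.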

Compound 3, largest response reached (reported as efficacy), in percent of the reference or control that the assay uses: 65.7%
Estimate against measurement, compound 3: 5.7 percentage points below, within the range that was stated.
By their numbers in this assay, from the lowest: compounds 1, 3 and 2 (each within the scatter of the next).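

Swapping 1,2-dimethylpropyl for 2-(3-methyloxetan-3-yl)ethyl on the amide-type nitrogen gives the first step that can be read at this place: in this assay it is a number 1 percentage points lower from compound 2 to compound 3 (within the scatter) and so too small to separate the two compounds. The change is not a minor one on paper, since it adds two heavy atoms, a four-membered non-aromatic ring with an oxygen and a hydrogen-bond acceptor, and removes the defined stereocentre, yet the maximal response stays within the scatter. Nothing measured here explains why these two chains read alike.

This single pair leaves open whether the same holds for groups of another kind on this nitrogen, such as a chain ending in an amine or a carboxylic acid, or a much longer alkyl chain. Among the compounds shown here, it also leaves open whether the swap would read the same on a different core, as the one other compound with a different chain on this nitrogen, compound 1, also differs at the far end of its alkyne and so cannot serve as a clean comparison.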